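Ester variants of the shared core: notes toward compound 3

A few compounds are considered here, and "the series" means these few. Any claim that something is new, unique, unknown or untested is made for them only; others in the source may bear on it.

Measured so far in a functional assay on MCF7 cells (Homo sapiens) for inhibition; a lower number here means a stronger inhibitor of growth, a higher number a weaker inhibitor of growth:
- compound 1 `CCOC(=O)c1ccsc1NC(=O)[C@@H]1CCCN1` gives > 250 ug/mL, which is a limit of the assay and not a number.
- compound 2 `O=C(Oc1ccccc1)c1ccsc1NC(=O)[C@@H]1CCCN1` gives > 250 ug/mL, again a limit of the assay rather than a number.

Going by the values given here, compound 1 therefore stands only at a limit in this assay; the one further value shown is also a limit, so the limit of > 250 ug/mL in this assay, at which 2 of the 2 values shown sit, describes both values.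

Among the compounds with values here, the one measured step, a step that the two limits leave unreadable from compound 1 to compound 2, is therefore unreadable in size; it tells nothing about how the ester oxygen substituent moves growth inhibition.

Compound 3 `O=C(OCC(F)(F)F)c1ccsc1NC(=O)[C@@H]1CCCN1` differs from compound 1 by trifluoromethyl in place of methyl on a saturated chain carbon bound to an oxygen next to a carbonyl group. Within the data shown here, no measured step bears on this particular change, and the only step is itself unreadable. Nothing in the shown values points to a step in either direction beyond the scatter.

Compound 3 is therefore expected to sit near the same limit, with an estimated 250 ug/mL, between 100 ug/mL and 600 ug/mL, corresponding to an expected step of a number no higher from compound 1 to compound 3 (the limit leaves the size open) from compound 1.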

Compound 3, concentration for 50% growth inhibition: 89.7 ug/mL
For compound 3 the middle estimate is 2.8-fold (0.45 log units) above the measured one; measured number below the stated range.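

In this assay, this position now gives a readable change: trifluoromethyl in place of methyl on a saturated chain carbon bound to an oxygen next to a carbonyl group gives an at least 2.7-fold lower number from compound 1 to compound 3 (0.44 log units; beyond the scatter). Setting 2,2,2-trifluoroethyl in place of phenyl on the same oxygen gives an at least 2.7-fold lower number from compound 2 to compound 3 (0.44 log units; beyond the scatter), so the group on this oxygen can move growth inhibition, which the unreadable step between the two earlier compounds could not show. Compound 3 is the only one of the three with a number rather than a limit, so both steps have a lower bound on their size and no upper bound: the limit of > 250 ug/mL in this assay, at which 2 of the 3 values shown sit.

From the compounds shown here alone, whether a 2-fluoroethyl or 2,2-difluoroethyl group on this oxygen, or a plain propyl chain, would also lower the number remains open, so the step cannot yet be tied to the count of fluorine atoms or to chain size. Also open, going by these compounds, is whether an amide or a carboxylic acid in place of the ester would retain growth inhibition in this assay.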